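This account rests on a few compounds, and the source may have more. Where it says the series, first, only, none or still open, it means among the compounds named here.

- compound 1 `NC(=S)N/N=C/c1ccc2ccccc2n1` with 960 nM
- compound 2 `S=C(N/N=C/c1ccc2ccccc2n1)Nc1ccc(Cl)cc1` with > 100000 nM (a limit of the assay)

In a functional assay on HeLa cells (Homo sapiens) for antiproliferative activity, read by sulforhodamine B assay, with a stated time of 72 h (on this read-out higher numbers stand for weaker inhibition and lower numbers for stronger inhibition), compound 2 stands at > 100000 nM, which is a limit and not a number. Going by the values given here, the one measured step, an at least 100-fold higher number from compound 1 to compound 2 (2.01 log units; beyond the scatter), is large and beyond the scatter, and it brought in the 4-chlorophenyl in place of hydrogen on an amide-type nitrogen. Compound 3 `Fc1ccc(NC(=S)N/N=C/c2ccc3ccccc3n2)cc1` keeps that nitrogen substituted and differs only by fluoro in place of chloro on an aromatic carbon, para to a large group. The large step to compound 2 an at least 100-fold higher number from compound 1 to compound 2 (2.01 log units; beyond the scatter) is expected to carry over to compound 3, so no step beyond the scatter is expected. The expected step is an at least 1.4-fold lower number from compound 2 to compound 3 (0.15 log units; that floor lies within the scatter). Compound 3 is estimated at 70000 nM, with an expected range from 10000 nM to 100000 nM.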

Compound 3, half-maximal inhibitory concentration: 33200 nM
Beside the measured number, compound 3's estimate is 2.1-fold (0.32 log units) above it; the range from low to high includes it.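

In this assay, replacing the chloro with fluoro on the aromatic ring gave an at least 3.0-fold lower number from compound 2 to compound 3 (0.47 log units; beyond the scatter), so the group at this place, para to a large group, does affect the read-out. The aryl substituent on the amide-type nitrogen still carries a large penalty with fluoro, as a 35-fold higher number from compound 1 to compound 3 (1.54 log units; beyond the scatter) shows, so the loss seen with the 4-chlorophenyl group is not confined to the chloro compound. Compound 2 stands at a limit of the assay and not at a number, so the step to compound 3 is only a floor: the limit of > 100000 nM in this assay, at which 1 of the 3 values shown sits.

On these data alone, it remains open whether an unsubstituted phenyl, or a phenyl carrying a methoxy or an amine at this place, would fall nearer compound 1 or compound 3. As far as these compounds go, it also remains open whether a methyl on that nitrogen would already cost as much as the aryl groups do.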